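The source may report more compounds than this note shows. Statements on the series, on what has been measured and on what is new or still open speak of the compounds shown alone.

Measured compounds and their values:
- Compound 1 `COc1ccc(C)cc1NC(=S)N/N=C/c1ccc2ccccc2n1`: in a functional assay on HT-29 cells (Homo sapiens) for antiproliferative activity, read by sulforhodamine B assay, with a stated time of 72 h (a lower number here means a stronger inhibitor, a higher number a weaker inhibitor), compound 1 gives only a limit of the assay, > 100000 nM.
- Compound 2 `S=C(N/N=C/c1ccc2ccccc2n1)Nc1cccc(Cl)c1`: in this assay compound 2 gives 48100 nM.
- Compound 3 `Cc1ccc(NC(=O)N/N=C/c2ccc3ccccc3n2)cc1`: in this assay compound 3 gives only a limit of the assay, > 100000 nM.

Among the measured compounds shown here, compound 2 is the only compound of the three with a measured number in this assay; the other two sit at the limit of > 100000 nM in this assay, at which 2 of the 3 values shown sit, which tells only that their potency is too weak to be read, not how weak. So compound 2 stands alone as the one point of reference, and it is itself a weak inhibitor.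

Compound 4 `S=C(N/N=C/c1ccc2ccccc2n1)Nc1ccccc1Br` has not yet been measured. It differs from compound 2 in one place: 2-bromophenyl in place of 3-chlorophenyl on an amide-type nitrogen. For the measured compounds named here, no pair of measured compounds differs in only one place, so there is no measured step on which to lean. The expectation is therefore cautious: a step from compound 2 to compound 4 of a size that does not go beyond the usual scatter, in no particular direction, with a fair chance that compound 4 also comes back as a limit rather than a number.

On that basis, the expected step from compound 2 to compound 4 is a 1.1-fold higher number from compound 2 to compound 4 (0.06 log units; within the scatter), and compound 4 is estimated at 55000 nM in this assay, with a range from 15000 nM to 150000 nM.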

Compound 4, half-maximal inhibitory concentration: > 100000 nM
Compound 4 gave a limit, no number; the forecaster's own chance of this, stated with the estimate: 40%; at least 1.8-fold (0.25 log units) between middle value and limit.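

In this assay, among the compounds shown here, changing 3-chlorophenyl to 2-bromophenyl on the amide-type nitrogen whose other neighbour is the thiocarbonyl carbon gives the only single-place comparison available here, and it reads as an at least 2.0-fold higher number from compound 2 to compound 4 (0.31 log units; beyond the scatter). For the compounds shown here, this shows that the group at this position matters: the one readable value in the set, that of compound 2, does not survive this change, even though the two groups have the same number of heavy atoms and the same ring. The size of the step is only a lower bound, as the value of compound 4 is a limit of the assay, and that limit is shared by most of the compounds: the limit of > 100000 nM in this assay, at which 3 of the 4 values shown sit.

The change alters both the halogen and the number in the group's name, so the compounds shown cannot separate the effect of bromine replacing chlorine from that of the halogen's place on the ring, and neither 3-bromophenyl nor 2-chlorophenyl is among them. Also open, on these data alone, is how unsubstituted phenyl or a phenyl ring carrying an amine or a carboxylic acid would read at this nitrogen.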